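Hydrogen for cyclopropyl on the compound 2 nitrogen

The compounds below may be only part of what the source reports. "The series", "measured", "known", "first", "only" and "open" are said of these compounds alone.

In an ADME assay on a cell-free system (plasma, Mus musculus) for protein binding, compound 1 (`CNc1nccc(N2CC[C@H](NC(=O)Nc3ccc(Cl)c(C(F)(F)F)c3)C2)n1`) gives 99.8% and compound 2 (`O=C(Nc1ccc(Cl)c(C(F)(F)F)c1)N[C@H]1CCN(c2ccnc(NC3CC3)n2)C1`) gives 99.9% so the two stand within the scatter of each other. Compound 3 (`Nc1nccc(N2CC[C@H](NC(=O)Nc3ccc(Cl)c(C(F)(F)F)c3)C2)n1`) carries hydrogen in place of cyclopropyl on a nitrogen on an aromatic ring with the rest of compound 2 unchanged. For the measured compounds named here, the one measured step on that nitrogen, cyclopropyl in place of methyl, is small (a 2.0-fold lower unbound fraction from compound 1 to compound 2 (0.30 log units; within the scatter)) and no measured compound has hydrogen there. A modest step towards more free compound is expected (a 3.0-fold higher unbound fraction from compound 2 to compound 3 (0.48 log units; beyond the scatter)) just beyond the scatter. For compound 3 the estimated value is 99.7% with an expected range from 99.2% to 99.9% in this assay as a working figure.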

Compound 3, plasma protein binding: 99.4%
Compound 3: the middle estimate sits 2.0-fold (0.30 log units) (unbound fraction) below what was measured, within the range that was stated.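

In this assay, for the compounds shown here, the plain amino group is the first change on this nitrogen to go beyond the scatter: hydrogen for cyclopropyl gives (a 6.0-fold higher unbound fraction from compound 2 to compound 3 (0.78 log units; beyond the scatter)) and hydrogen for methyl gives (a 3.0-fold higher unbound fraction from compound 1 to compound 3 (0.48 log units; beyond the scatter)). Methyl and cyclopropyl stay within the scatter of each other, so in these three compounds the clear separation lies between hydrogen and either carbon group. Nothing measured here accounts for this shift.

Open, on these data alone, is whether a longer chain such as ethyl, or an acetyl group, on this nitrogen stays with methyl and cyclopropyl or moves towards hydrogen.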